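Thiophen-2-yl to pyridin-3-yl in the hydroxyphenyl series

A few compounds are considered here, and "the series" means these few. Any claim that something is new, unique, unknown or untested is made for them only; others in the source may bear on it.

Values in a functional assay on HCT-15 cells (Homo sapiens) for cytotoxicity, read by ELISA, with a stated time of 2 days; on this read-out lower numbers stand for stronger inhibition and higher numbers for weaker inhibition:
- compound 1 `Oc1ccccc1-c1cc(-c2ccccc2)cc(-c2ccccc2O)n1`: > 50000 nM (a limit)
- compound 2 `Oc1cccc(-c2cc(-c3ccccc3)cc(-c3cccs3)n2)c1`: 10900 nM
- compound 3 `Oc1ccc(-c2cc(-c3ccccc3)cc(-c3cccs3)n2)cc1`: 12500 nM

Among the compounds with values here, only two of these values are numbers, and they lie within the scatter of each other: a 1.1-fold higher number from compound 2 to compound 3 (0.06 log units; within the scatter). Compound 3 therefore has a single numeric neighbour and no order can be read from the pair. Compound 1 gives > 50000 nM, which is a limit and not a number.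

Compound 4 `Oc1ccc(-c2cc(-c3ccccc3)cc(-c3cccnc3)n2)cc1` derives from compound 3 by one change: pyridin-3-yl in place of thiophen-2-yl on an aromatic carbon. Pyridin-3-yl stands in place of thiophen-2-yl on an aromatic carbon, next to the ring nitrogen.

Within the data shown here, no measured step changes the group at this place. Among the measured compounds shown here, the one measured step, a 1.1-fold higher number from compound 2 to compound 3 (0.06 log units; within the scatter), concerns the hydroxyphenyl group instead, so it bears on this change only loosely. It does show a small response in this assay to a change elsewhere on the shared core. With compound 3 at 12500 nM as the anchor, no shift beyond the scatter is expected, though the uncertainty is wide. The expected step is a 1.2-fold higher number from compound 3 to compound 4 (0.08 log units; within the scatter). For compound 4 the estimated value is 15000 nM, with an expected range of 5000 nM to 45000 nM.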

Compound 4, half-maximal inhibitory concentration: 15100 nM
The estimate for compound 4 lay 1.0-fold (0.00 log units) below the measured number, and the stated range covers the measured number.
By their numbers in this assay, from the lowest: compounds 2, 3 and 4 (each within the scatter of the next). At a limit, above all of these: compound 1.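

In this assay, within the data shown here, the only measured step at this place, pyridin-3-yl in place of thiophen-2-yl, gives a 1.2-fold higher number from compound 3 to compound 4 (0.08 log units; within the scatter). Among these compounds, the earlier step varied only the hydroxyphenyl group, so this is the sole reading at the aromatic carbon next to the ring nitrogen, and it separates neither group from the other: with a 4-hydroxyphenyl group on the shared core, a five-membered aromatic ring carrying sulfur and a six-membered aromatic ring carrying nitrogen cannot be told apart in this assay. Compound 4 gives a number and not a limit, so this step can be read, whereas only compound 1 stands at a limit: the limit of > 50000 nM in this assay, at which 1 of the 4 values shown sits.

On these data alone, whether any group at this place can move the number beyond the scatter remains open, since both groups compared are single aromatic rings, and an amine, a carboxylic acid or a longer chain would test a different kind of substituent. Also open is whether pyridin-3-yl behaves the same way alongside a 3-hydroxyphenyl group, as that pairing does not appear among the compounds shown.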